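Carbamate chain variation and maximal response in a receptor assay

The source may report more compounds than this note shows. Statements on the series, on what has been measured and on what is new or still open speak of the compounds shown alone.

Measured compounds:
Compound 1, `CCOC(=O)N1CCC(Oc2ncnc3c2CCN3c2ccc(S(C)(=O)=O)cc2F)CC1`, gives 135% in a functional assay on CHO-K1 cells with Glucose-dependent insulinotropic receptor (Homo sapiens) as the target, read by a luciferase reporter, with a stated time of 5 h; a higher number here means a larger maximal response, a lower number a smaller maximal response.
Compound 2, `CCCCOC(=O)N1CCC(Oc2ncnc3c2CCN3c2ccc(S(C)(=O)=O)cc2F)CC1`, gives 131% in this assay.

Compound 2 stands lowest of the two numbers, with compound 1 nearest; the step of a number 4 percentage points lower from compound 1 to compound 2 (within the scatter) lies within the scatter, so the two values cannot be told apart with confidence.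

Compound 3, `CC(C)(C)COC(=O)N1CCC(Oc2ncnc3c2CCN3c2ccc(S(C)(=O)=O)cc2F)CC1`, is not yet measured. It differs from compound 2 by tert-butyl in place of propyl on a saturated chain carbon bound to an oxygen next to a carbonyl group. Within the data shown here, the only measured step that bears on it is the one from compound 1 to compound 2, which also lengthened the chain at the same part of the molecule and was within the scatter. On that basis the step to compound 3 is expected to be a number 1 percentage points lower from compound 2 to compound 3 (within the scatter), that is, no movement beyond the scatter in either direction. Compound 3 is therefore estimated to give 130% in this assay, with a range from 115% to 145%.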

Compound 3, largest response reached (reported as percent of maximum), in percent of the reference or control that the assay uses: 80%
Beside the measured number, compound 3's estimate is 50 percentage points above it, and the stated range ends above it.
By their numbers in this assay, from the lowest: compound 3; then compounds 2 and 1 (each within the scatter of the next).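

In this assay, compound 1 and compound 2 alone gave no sign that this place mattered, yet the change to neopentyl brings a number 51 percentage points lower from compound 2 to compound 3 (beyond the scatter) and, measured against the ethyl carbamate, a number 55 percentage points lower from compound 1 to compound 3 (beyond the scatter) in the same read-out. The place, a saturated chain carbon bound to an oxygen next to a carbonyl group, is therefore sensitive to the form of the chain: the ethyl of compound 1 and the butyl of compound 2 stand within the scatter of each other, while the neopentyl of compound 3 stands clearly under both. Nothing measured here accounts for this drop in maximal response.

The compounds shown leave open whether a smaller branched chain such as isopropyl or isobutyl would also lower the response, or whether a longer straight chain such as hexyl would stay level with compound 1 and compound 2. They also leave open whether a ring-bearing chain such as cyclopropylmethyl would follow neopentyl or the straight chains.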